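Amide substituent change from compound 2 to compound 3

A few compounds are considered here, and "the series" means these few. Any claim that something is new, unique, unknown or untested is made for them only; others in the source may bear on it.

Measured in an ADME assay on LLC-MK2 cells (Macaca mulatta) for cytotoxicity, read by spectrophotometry and crystal violet staining, with a stated time of 4 days; a lower number here means that less compound is tolerated, a higher number that more compound is tolerated:
compound 1 `CC(C)n1ncc2c(C(=O)Nc3c(F)cc(F)cc3F)cc(-c3cccs3)nc21`: > 200000 nM (a limit of the assay)
compound 2 `CC(C)n1ncc2c(C(=O)Nc3cc(F)ccc3F)cc(-c3cccs3)nc21`: 100000 nM

Going by the values given here, compound 2 , at 100000 nM, carries the only true number so far. The entry for compound 1 is a limit and not a number. Compound 3 `CC(C)n1ncc2c(C(=O)Nc3ccc(F)cn3)cc(-c3cccs3)nc21` is not yet measured. It carries 5-fluoropyridin-2-yl in place of 2,5-difluorophenyl on an amide-type nitrogen. Among the compounds with values here, one measured step bears on this, since it changes the group at the same place: an at least 2.0-fold lower number from compound 1 to compound 2 (0.30 log units; that floor lies within the scatter). That step gives only a floor, and it offers no firm ground for a shift in either direction. The expected step is therefore none beyond the scatter: no change at the digits printed from compound 2 to compound 3 (within the scatter). For compound 3 the estimated value is 100000 nM, with an expected range of 40000 nM to 200000 nM.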

Compound 3, half-maximal cytotoxic concentration: > 200000 nM
Compound 3 was reported as a limit (the forecaster's own chance of this, stated with the estimate: 30%); at least 2.0-fold (0.30 log units) between middle value and limit.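

In this assay, 5-fluoropyridin-2-yl in place of 2,5-difluorophenyl on the amide-type nitrogen gives an at least 2.0-fold higher number from compound 2 to compound 3 (0.30 log units; that floor lies within the scatter). Compound 3 thus shows that a ring with a hetero atom at this place can reach the same assay limit as the carbon-only ring of compound 1, while the carbon-only ring of compound 2 gives a true number; the series offers no simple split between the two ring types, and the readout is capped: the limit of > 200000 nM in this assay, at which 2 of the 3 values shown sit. The two limits leave the step between compound 1 and compound 3 unreadable.

On these data alone, how far compound 1 and compound 3 lie past that limit stays open. Also open, as far as these compounds go, is whether an unsubstituted pyridin-2-yl or a cyclohexyl group on the amide-type nitrogen would give a true number or the limit.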